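The source may hold more compounds than are shown below. What is called first, only, known or untested is meant among the compounds shown, and "the series" means these compounds.

Measured so far in an assay on CHO-K1 cells for displacement of a labelled ligand from adenosine receptor A1 (Homo sapiens), read by scintillation counting, with a stated time of 60 min; a lower number here means a stronger inhibitor, a higher number a weaker inhibitor:
compound 1 `CCCCC/C=C/C=C/C=N/Nc1nc(N)c2ncn([C@@H]3O[C@H](CO)[C@@H](O)[C@H]3O)c2n1` — 2 nM
compound 2 `CC(/C=N/Nc1nc(N)c2ncn([C@@H]3O[C@H](CO)[C@@H](O)[C@H]3O)c2n1)Cc1ccc(C(C)C)cc1` — 9500 nM
compound 3 `Nc1nc(N/N=C/c2ccc(-c3ccc(Br)cc3)o2)nc2c1ncn2[C@@H]1O[C@H](CO)[C@@H](O)[C@H]1O` — 4.5 nM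

Compound 1 gives the lowest number of the three in this assay; compound 3 stands closest to it, and that gap is beyond the scatter, while compound 2 lies far beyond the scatter above both.

Compound 4 `CCOc1cc(/C=N/Nc2nc(N)c3ncn([C@@H]4O[C@H](CO)[C@@H](O)[C@H]4O)c3n2)ccc1O` has not yet been measured. It differs from compound 1 in one place: a group of 10 heavy atoms (8 carbon, 2 oxygen; one six-membered aromatic ring of carbon only) in place of a group of 9 heavy atoms (9 carbon; no ring), on a carbon with a double bond to nitrogen. For the measured compounds named here, no measured pair shows this exact step. Compound 3 shows that an aromatic ring on the hydrazone carbon can still give a low number in this assay, whereas compound 2 shows how far a different replacement can move it. A modest rise is expected, with the step from compound 1 to compound 4 estimated as a 7.5-fold higher number from compound 1 to compound 4 (0.88 log units; beyond the scatter). Compound 4 is expected to give about 15 nM, within 3 nM to 80 nM.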

Compound 4, inhibition constant: 6940 nM
The estimate for compound 4 lay 460-fold (2.67 log units) below the measured number; measured number outside the range, above it.
By their numbers in this assay, from the lowest: compound 1; then compound 3; then compounds 4 and 2 (each within the scatter of the next).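

On the carbon with a double bond to nitrogen, 3-ethoxy-4-hydroxyphenyl in place of the open chain of 9 heavy atoms gives a 3500-fold higher number from compound 1 to compound 4 (3.54 log units; beyond the scatter) in this assay and so removes nearly all of the affinity seen with the chain. An aromatic ring on this carbon does not by itself keep the number low: compound 3 gives 4.5 nM and compound 4 gives 6940 nM. No available data explain this rise.

Open, from the compounds shown here alone, is how an unsubstituted phenyl or a 4-hydroxyphenyl would read on this carbon, and so which part of the 3-ethoxy-4-hydroxyphenyl group goes with the higher number. A shorter alkenyl chain on this carbon would show how much of the chain of compound 1 the low number needs.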